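The source may report more compounds than this note shows. Statements on the series, on what has been measured and on what is new or still open speak of the compounds shown alone.

Measured so far in an assay on isolated protein for inhibition of serine/threonine-protein kinase TNNI3K (Homo sapiens); a lower number here means a stronger inhibitor, a higher number a weaker inhibitor:
compound 1, `CNc1cc(Oc2ccc(NC(=O)Nc3cccc(C)c3)cc2)ncn1`; compound 1 gives 1260 nM
compound 2, `O=C(Nc1ccc(Oc2ccncn2)cc1)Nc1cccc(C(F)(F)F)c1`; compound 2 gives 160 nM
compound 3, `CNc1cc(Oc2cc(C)c(NC(=O)Nc3cccc(C(F)(F)F)c3)cc2C)ncn1`; compound 3 gives 32 nM

Compound 2 stands second highest of the three numbers. Its nearest neighbour is compound 3, whose number is lower by an amount beyond the usual scatter; the furthest is compound 1, whose number is higher, again beyond the scatter. For the measured compounds named here, no two of the measured compounds differ in only one place, so no single measured step is at hand to lean on.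

Compound 4, `O=C(Nc1ccc(Oc2ccncc2)cc1)Nc1cccc(C(F)(F)F)c1`, is not yet measured. It differs from compound 2 in one place: pyridin-4-yl in place of pyrimidin-4-yl on an oxygen on an aromatic ring. The urea and the trifluoromethyl are untouched; the change is confined to the group on the oxygen.

Going by the values given here, with no measured pair that isolates this change, the expectation rests on compound 2 alone, whose number in this assay is 160 nM. The step from compound 2 to compound 4 is expected to be small, toward a higher number, at about a 1.9-fold higher number from compound 2 to compound 4 (0.27 log units; within the scatter), though a result within the scatter would not surprise. Compound 4 is therefore expected to give 300 nM, within a range of 80 nM to 1200 nM.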

Compound 4, half-maximal inhibitory concentration: 50 nM
Compound 4: the middle estimate sits 6.0-fold (0.78 log units) above what was measured, outside the stated range (below it).
By their numbers in this assay, from the lowest: compounds 3 and 4 (each within the scatter of the next); then compound 2; then compound 1.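

In this assay, for the compounds shown here, the change from pyrimidin-4-yl to pyridin-4-yl on an oxygen on an aromatic ring gives a 3.2-fold lower number from compound 2 to compound 4 (0.51 log units; beyond the scatter) and is the first step that isolates a single place, showing that the number responds to the group on this oxygen even with the urea and the trifluoromethyl held fixed. The heavy-atom count stays the same while one hetero atom and one hydrogen-bond acceptor leave, and inhibition improves beyond the scatter, so the second ring nitrogen of pyrimidin-4-yl is not required for inhibition at this level in this scaffold. Nothing measured here accounts for the gain.

Going by these compounds, whether the one remaining ring nitrogen of pyridin-4-yl matters stays open, and a plain phenyl on the same oxygen, or pyridin-3-yl as the isomeric ring, would separate the presence of that nitrogen from its place in the ring. Also open, on these data alone, is whether the same step holds on the other cores of the series, such as the core of compound 3, and whether a small amine on the pyridin-4-yl ring changes the number.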